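The source may hold more compounds than are shown below. What is called first, only, known or untested is meant among the compounds shown, and "the series" means these compounds.

The series shares one core and varies the group on the sulfonyl sulfur. Compound 1 `O=C(NCc1ccc(S(=O)(=O)c2ccccc2)cc1)NCc1cccnc1` gives 19 nM in an assay on isolated protein for inhibition of Nicotinamide phosphoribosyltransferase (Homo sapiens), read by mass spectrometry, with stated times of 15 min and 30 min; on this read-out higher numbers stand for weaker inhibition and lower numbers for stronger inhibition. Compound 2 `O=C(NCc1ccc(S(=O)(=O)C2CCOCC2)cc1)N1Cc2ccncc2C1` gives 26 nM in this assay, and compound 3 `CN1CCC(S(=O)(=O)c2ccc(CNC(=O)N3Cc4ccncc4C3)cc2)CC1` gives 48 nM in this assay. Going by the values given here, the numbers for compound 1 and compound 2 lie close together, and the step of a 1.8-fold higher number from compound 2 to compound 3 (0.27 log units; within the scatter) is the only measured change at the sulfonyl sulfur; it stays within the scatter, so the three compounds cannot be separated on these data.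

Compound 4 `CN1CCN(S(=O)(=O)c2ccc(CNC(=O)N3Cc4ccncc4C3)cc2)CC1` has not yet been measured. It differs from compound 2 as 4-methylpiperazin-1-yl in place of oxan-4-yl on a sulfonyl sulfur. Among the compounds with values here, the one step that bears on this, a 1.8-fold higher number from compound 2 to compound 3 (0.27 log units; within the scatter), swapped the oxan-4-yl for another six-membered ring without moving the number beyond the scatter. A similar outcome is therefore expected for the step of a 1.5-fold higher number from compound 2 to compound 4 (0.19 log units; within the scatter), with no clear direction. In this assay compound 4 is expected to give about 40 nM, with a likely range from 15 nM to 110 nM.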

Compound 4, half-maximal inhibitory concentration: 38 nM
Compound 4: middle estimate off by 1.1-fold (0.02 log units), on the high side, and the stated range covers the measured number.
By their numbers in this assay, from the lowest: compounds 1, 2, 4 and 3 (each within the scatter of the next, the first and the last beyond it).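

In this assay the swap of oxan-4-yl for 4-methylpiperazin-1-yl gives a 1.5-fold higher number from compound 2 to compound 4 (0.16 log units; within the scatter) and the swap of 1-methylpiperidin-4-yl for the same group gives a 1.3-fold lower number from compound 3 to compound 4 (0.10 log units; within the scatter) on the shared core. A third six-membered non-aromatic ring on the sulfonyl sulfur, here with two hetero atoms, thus cannot be separated from either of the other two, so no change of ring at this position has yet moved the number beyond the scatter. Nothing available explains why these rings read alike.

From the compounds shown here alone, all three of these groups are six-membered non-aromatic rings, so the effect of an open chain on the sulfonyl sulfur, such as a longer alkyl chain, remains open. So does the effect of a carboxylic acid or a primary amine carried on such a ring.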